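Acyl variation on the carbonyl carbon: tert-butyl for cyclopentyl

This account rests on a few compounds, and the source may have more. Where it says the series, first, only, none or still open, it means among the compounds named here.

Measured compounds:
compound 1 `COc1ncc(-c2ccc3ncnc(N[C@H]4CCN(C(=O)C5CCOCC5)C4)c3c2)cc1NS(C)(=O)=O` — 1500 nM
compound 2 `COc1ncc(-c2ccc3ncnc(N[C@H]4CCN(C(C)=O)C4)c3c2)cc1NS(C)(=O)=O` — >= 100000 nM, which is a limit of the assay and not a number
compound 3 `COc1ncc(-c2ccc3ncnc(N[C@H]4CCN(C(=O)C5CCCC5)C4)c3c2)cc1NS(C)(=O)=O` — 770 nM

In a functional assay on SU-DHL-6 cells (Homo sapiens) for antiproliferative activity, read by CCK-8 assay, with a stated time of 72 h (a lower number here means a stronger inhibitor, a higher number a weaker inhibitor), the three compounds differ only in the group on the carbonyl carbon. Compound 3 stands lowest of the two numbers shown; its nearest neighbour is compound 1, with a 1.9-fold lower number from compound 1 to compound 3 (0.29 log units; within the scatter). Compound 2 sits at the limit of >= 100000 nM in this assay, at which 1 of the 3 values shown sits. The step of an at least 120-fold lower number from compound 2 to compound 3 (2.11 log units; beyond the scatter) is large and beyond the scatter, while a 1.9-fold lower number from compound 1 to compound 3 (0.29 log units; within the scatter) is not.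

Compound 4 `COc1ncc(-c2ccc3ncnc(N[C@H]4CCN(C(=O)C(C)(C)C)C4)c3c2)cc1NS(C)(=O)=O` carries the change (tert-butyl in place of cyclopentyl on a carbonyl carbon). The step that bears on it is an at least 120-fold lower number from compound 2 to compound 3 (2.11 log units; beyond the scatter), which shows that the smallest group on this carbon gives a far higher number, whereas a 1.9-fold lower number from compound 1 to compound 3 (0.29 log units; within the scatter) shows that two larger groups, one a ring with an oxygen and one a carbon ring, give numbers within the scatter of each other. Tert-butyl, with four heavy atoms and no ring, is expected to behave more like cyclopentyl than like methyl, so no step beyond the scatter is expected, with a 1.6-fold higher number from compound 3 to compound 4 (0.19 log units; within the scatter) as the estimated step. Compound 4 is therefore expected to give about 1200 nM, in a range from 400 nM to 4000 nM.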

Compound 4, half-maximal inhibitory concentration: 7600 nM
For compound 4 the middle estimate is 6.3-fold (0.80 log units) below the measured one, outside the stated range (above it).
By their numbers in this assay, from the lowest: compounds 3 and 1 (each within the scatter of the next); then compound 4. At a limit, above all of these: compound 2.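

In this assay the group on the carbonyl carbon is not read by size alone: a 9.9-fold higher number from compound 3 to compound 4 (0.99 log units; beyond the scatter) and a 5.1-fold higher number from compound 1 to compound 4 (0.70 log units; beyond the scatter) set tert-butyl, which has no ring, apart from both cyclopentyl and oxan-4-yl. At the same time an at least 13-fold lower number from compound 2 to compound 4 (1.11 log units; beyond the scatter) keeps tert-butyl well clear of methyl, so it takes an intermediate place in this short series. That last step rests on a limit of the assay and not on a number for compound 2: the limit of >= 100000 nM in this assay, at which 1 of the 4 values shown sits.

Whether the ring itself or the branching of tert-butyl accounts for the gap stays open, and cyclopropyl, phenyl or a longer chain such as n-butyl on the carbonyl carbon would bear on this. On these data alone, how an amine or a carboxylic acid on the cyclopentyl ring would read also remains open.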